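The source may hold more compounds than are shown below. What is called first, only, known or untested is meant among the compounds shown, and "the series" means these compounds.

Two compounds measured in a functional assay on NCI-H1581 cells (Homo sapiens) for inhibition, read by MTT assay, with a stated time of 48 h, tested at 10 uM (on this read-out lower numbers stand for less inhibition and higher numbers for more inhibition at the one concentration tested (going by the name of the read-out)), open the series. Compound 1 `CCc1ccc(Nc2cc(NC(=O)Nc3cc(OC)cc(OC)c3)ncn2)cc1` gives 32.7% and stands lowest of the two numbers. Compound 2 `COc1ccc(Br)cc1Nc1cc(NC(=O)Nc2c(Cl)cccc2Cl)ncn1` gives 53.3%, which lies beyond the usual scatter above compound 1; since compound 2 differs from compound 1 in several places at once, its number can only be read as a second point in the same range, not as the effect of any one change.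

Within the data shown here, compound 3 `COc1cc(NC(=O)Nc2cc(Nc3ccc(OC)c(C)c3)ncn2)cc(OC)c1` is the first compound in which only one place is changed from compound 1: 4-methoxy-3-methylphenyl in place of 4-ethylphenyl on a nitrogen on an aromatic ring. Among the measured compounds shown here, no pair of measured compounds shows what such a swap does, so the size of the step can only be guessed. The group that enters is similar in size to the one that leaves, and the rest of the structure is the same, so for compound 3 the expected step of a number 5.3 percentage points higher from compound 1 to compound 3 (within the scatter) is small, likely within the scatter, if anything toward somewhat more inhibition. In this assay compound 3 is therefore estimated at 38%, with a range from 20% to 58%.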

Compound 3, a percentage reported as inhibition, at one concentration (the size of the read-out at that concentration, not a potency): 19.7%
Beside the measured number, compound 3's estimate is 18.3 percentage points above it, and the stated range ends above it.
By their numbers in this assay, from the lowest: compound 3; then compound 1; then compound 2.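

At this position, on a nitrogen on an aromatic ring, the first single change gives a real difference: in this assay the swap of 4-ethylphenyl for 4-methoxy-3-methylphenyl gives a number 13 percentage points lower from compound 1 to compound 3 (beyond the scatter), a modest step but one that can be read. The two groups share one six-membered aromatic ring of carbon only, and the entering group has just one more heavy atom, an oxygen, which adds one hydrogen-bond acceptor, so even this small difference in the group on that nitrogen is enough to lower the inhibition measured at the one concentration tested. No measurement shown gives a reason for the fall.

The swap removes the ethyl group and brings in both a methoxy and a methyl group, so these compounds cannot tell which of those parts goes with the lower number. From the compounds shown here alone, it also remains open whether a different group at this place, such as an amine or a carboxylic acid on the same phenyl ring, would take the number further down or bring it back up.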